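Moving the trifluoromethyl group on a phenoxy arm

This account rests on a few compounds, and the source may have more. Where it says the series, first, only, none or still open, it means among the compounds named here.

For the measured compounds named here, compound 2 `CCc1nc(Cl)c2n1CCN([C@@H](C(=O)NC)c1ccccc1)[C@H]2COc1ccc(C(F)(F)F)cc1` gives 431 nM in a functional assay on CHO cells for antagonist activity at Orexin/Hypocretin receptor type 1 (Homo sapiens), read by FLIPR and calcium flux (on this read-out lower numbers stand for stronger inhibition and higher numbers for weaker inhibition), the highest of the two numbers so far. Compound 1 `CCc1nc(Cl)c2n1CCN([C@@H](C(=O)NC)c1ccccc1)[C@H]2CCc1cccc(C(F)(F)F)c1` gives 72 nM. Compound 3 `CCc1nc(Cl)c2n1CCN([C@@H](C(=O)NC)c1ccccc1)[C@H]2COc1cccc(C(F)(F)F)c1` differs from compound 2 by 3-(trifluoromethyl)phenyl in place of 4-(trifluoromethyl)phenyl on an oxygen on a saturated carbon. Going by the values given here, the only measured step, a 6.0-fold higher number from compound 1 to compound 2 (0.78 log units; beyond the scatter), changes more than one thing at once, so it bears only loosely on this change and leaves the direction open. A step no larger than that one is expected, a 2.2-fold lower number from compound 2 to compound 3 (0.33 log units; beyond the scatter). For compound 3 a value of 200 nM is estimated, within 70 nM to 600 nM.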

Compound 3, half-maximal inhibitory concentration: 312 nM
For compound 3 the middle estimate is 1.6-fold (0.19 log units) below the measured one; low and high end bracket the measured number.
By their numbers in this assay, from the lowest: compound 1; then compounds 3 and 2 (each within the scatter of the next).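

Moving the trifluoromethyl group on the phenoxy arm gives a 1.4-fold lower number from compound 2 to compound 3 (0.14 log units; within the scatter) in this assay, so the two placements cannot be told apart here. With the 3-(trifluoromethyl) naming unchanged, going to the phenoxy arm gives a 4.3-fold higher number from compound 1 to compound 3 (0.64 log units; beyond the scatter), which ties the gap to 3-(trifluoromethyl)phenoxy in place of 3-(trifluoromethyl)benzyl alone, a cleaner comparison than the earlier step. No available evidence explains either result.

Still open, as far as these compounds go, is how the arm behaves with a nitrile or a methoxy group in place of trifluoromethyl, or with an amine in place of the oxygen.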